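The compounds below may be only part of what the source reports. "The series", "measured", "known", "first", "only" and "open" are said of these compounds alone.

Measured compounds:
compound 1, `Cc1cc(Nc2ccn(Cc3cccc4ccccc34)n2)n2nc(SCc3ccc(Br)cc3)nc2n1`, 5660 nM
compound 2, `Cc1cc(Nc2cc(-c3ccccc3)[nH]n2)n2nc(SCc3c(Cl)cccc3Cl)nc2n1`, 5180 nM

In a functional assay on PC-9 cells (Homo sapiens) for inhibition, read by MTT assay, with a stated time of 72 h (a higher number here means a weaker inhibitor, a lower number a stronger inhibitor), compound 1 gives 5660 nM and compound 2 gives 5180 nM. Compound 2 holds the lower of the two numbers, but its gap to compound 1 is within the scatter, so the two cannot be ordered. Compound 3 is `Cc1cc(Nc2cc(-c3ccccc3)[nH]n2)n2nc(SCc3ccccc3Br)nc2n1`, not yet measured in this assay. It differs from compound 2 in one place: 2-bromophenyl in place of 2,6-dichlorophenyl on a saturated chain carbon bound to a sulfur; cut one bond further out, (2,6-dichlorobenzyl)sulfanyl becomes (2-bromobenzyl)sulfanyl. Within the data shown here, no measured pair shows what such an exchange does here, and the two measured numbers, which carry different groups at this position, sit within the scatter of each other. Compound 3 is therefore expected to stay close to compound 2, with a step of a 1.2-fold higher number from compound 2 to compound 3 (0.06 log units; within the scatter) that need not exceed the scatter. For compound 3 the estimate in this assay is 6000 nM, in the range 2500 nM to 15000 nM.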

Compound 3, half-maximal inhibitory concentration: 5630 nM
Compound 3: middle estimate off by 1.1-fold (0.03 log units), on the high side, and the stated range covers the measured number.
By their numbers in this assay, from the lowest: compounds 2, 3 and 1 (each within the scatter of the next).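

In this assay, among these compounds, the exchange of 2,6-dichlorophenyl for 2-bromophenyl on a saturated chain carbon bound to a sulfur gives a 1.1-fold higher number from compound 2 to compound 3 (0.04 log units; within the scatter) as the first one-place comparison at this position. With the rest of compound 2 held fixed, this particular exchange of two chlorine atoms for one bromine atom therefore produces no step beyond the scatter. No measurement bears on why the two numbers agree.

From the compounds shown here alone, whether the number at this position responds to a group of another kind remains open, for example an amine or a carboxylic acid in place of the bromine, or a longer chain between the sulfur and the ring. Compound 1 differs from compound 2 in more than one place, so it cannot settle either question.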